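Linear versus branched amide chain on the shared core

A few compounds are considered here, and "the series" means these few. Any claim that something is new, unique, unknown or untested is made for them only; others in the source may bear on it.

Compound 2 `CCC1C(=O)N(C)c2cnc(-n3ccc4cc(C(=O)NCC(C)C)ccc43)nc2N1c1ccn(C)n1` stands second highest of the three numbers in a functional assay on K562 cells (Homo sapiens) for antiproliferative activity, read by CCK-8 assay, with a stated time of 72 h (on this read-out lower numbers stand for stronger inhibition of growth and higher numbers for weaker inhibition of growth), where compound 2 gives 5600 nM. In this assay compound 1 `CCC1C(=O)N(C)c2cnc(-n3ccc4cc(C(=O)NC)ccc43)nc2N1c1ccn(C)n1` gives 13300 nM, and compound 3 `CCCNS(=O)(=O)c1ccc(Nc2ncc3c(n2)N(c2ccn(C)n2)C(CC)C(=O)N3C)cc1`, which joins a different arm to the shared core, gives 2260 nM. Among the measured compounds shown here, the one measured step on the amide chain is a 2.4-fold lower number from compound 1 to compound 2 (0.38 log units; beyond the scatter), a modest move in favor of the larger group. Compound 4 `CCCCNC(=O)c1ccc2c(ccn2-c2ncc3c(n2)N(c2ccn(C)n2)C(CC)C(=O)N3C)c1` differs from compound 2 by propyl in place of isopropyl on a saturated chain carbon bound to an amide-type nitrogen. For the measured compounds named here, the step from compound 1 to compound 2 concerns adding carbon at this place, not how that carbon is arranged; no measured pair sets a branched chain against a straight one of the same size, and with the same atoms joined differently the step in this assay is expected to stay within the scatter, in either direction. Compound 4 is therefore expected to give 5000 nM in this assay, within 2500 nM to 10000 nM. The expected step is a 1.1-fold lower number from compound 2 to compound 4 (0.05 log units; within the scatter).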

Compound 4, concentration for 50% growth inhibition: 14100 nM
Compound 4: middle estimate off by 2.8-fold (0.45 log units), on the low side; the measured number lies above the stated range.
By their numbers in this assay, from the lowest: compound 3; then compound 2; then compounds 1 and 4 (each within the scatter of the next).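

In this assay, how the same carbons are joined at this place counts: butylcarbamoyl in place of isobutylcarbamoyl gives a 2.5-fold higher number from compound 2 to compound 4 (0.40 log units; beyond the scatter), a modest step. Added carbon alone therefore does not account for a 2.4-fold lower number from compound 1 to compound 2 (0.38 log units; beyond the scatter), since the straight chain gives a 1.1-fold higher number from compound 1 to compound 4 (0.03 log units; within the scatter), which leaves compound 4 level with compound 1. Among these three amides, the isobutyl chain of compound 2 alone stands apart, and only by a modest margin.

No measurement at hand explains the difference between the two chains. Still open, from the compounds shown here alone, is whether a more heavily branched chain such as neopentyl, a ring-bearing chain such as cyclopropylmethyl, or a longer chain such as pentyl would track compound 2 or compound 4 on this read-out.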